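Nitro in place of chloro on the fused ring

This account rests on a few compounds, and the source may have more. Where it says the series, first, only, none or still open, it means among the compounds named here.

Measured so far in an assay for inhibition of Alpha amylase (Homo sapiens), with a stated time of 10 min; on this read-out higher numbers stand for weaker inhibition and lower numbers for stronger inhibition:
compound 1 `COc1cccc(-c2nc3ccccc3[nH]2)c1Cl` — compound 1 gives 2740 nM
compound 2 `COc1cccc(-c2nc3cc(Cl)ccc3[nH]2)c1Cl` — compound 2 gives 2780 nM

Compound 2 and compound 1 sit together on the numbers shown: the single measured step, a 1.0-fold higher number from compound 1 to compound 2 (0.01 log units; within the scatter), lies within the scatter, so the two cannot be told apart and no order between them is claimed.

Compound 3 `COc1cccc(-c2nc3cc([N+](=O)[O-])ccc3[nH]2)c1Cl` differs from compound 2 by nitro in place of chloro on an aromatic carbon. Among the compounds with values here, the only measured step that bears on this position is a 1.0-fold higher number from compound 1 to compound 2 (0.01 log units; within the scatter), which put the chloro in place of hydrogen there and produced no change beyond the scatter. Within the data shown here, no measured step involves a nitro anywhere, so nothing in the data points in either direction for the present exchange; the one relevant step speaks for this position tolerating substitution without a shift.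

Compound 3 is therefore expected to give about 2600 nM, in the range 1000 nM to 6500 nM, an estimated step of a 1.1-fold lower number from compound 2 to compound 3 (0.03 log units; within the scatter) and no change beyond the scatter.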

Compound 3, half-maximal inhibitory concentration: 2780 nM
Estimate against measurement, compound 3: 1.1-fold (0.03 log units) below; the range from low to high includes it.
By their numbers in this assay, from the lowest: compounds 1, 2 and 3 (each within the scatter of the next).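

Notes on this position: in this assay the exchange of chloro for nitro gives no change at the digits printed from compound 2 to compound 3 (within the scatter) and the comparison with the unsubstituted parent gives a 1.0-fold higher number from compound 1 to compound 3 (0.01 log units; within the scatter). Until now this aromatic carbon had been probed with chloro alone, so the flat read-out could have been specific to that one atom. It now also holds for nitro, which brings three heavy atoms and two hydrogen-bond acceptors where chloro brought one heavy atom and none, and hydrogen, chloro and nitro cannot be told apart here.

Still open, on these data alone, is whether this indifference extends to an amine or a carboxylic acid on the same carbon, or to a longer chain, any of which would test the position with a different kind of group. As far as these compounds go, all three compounds also share the rest of the core of compound 1, so whether the position behaves the same way with a change elsewhere on that core remains unknown. No evidence is available to explain why the numbers stay level across these three compounds.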